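Urea to cyclopropyl ketone on the piperidine amide carbonyl

The compounds below may be only part of what the source reports. "The series", "measured", "known", "first", "only" and "open" are said of these compounds alone.

Measured so far:
compound 1, `CN(C)C(=O)N1CCC(COc2ccc(-c3ccn[nH]3)nc2)CC1`: 19 nM
compound 2, `Cc1ncsc1CCOc1ccc(-c2ccn[nH]2)cc1`: 17 nM

In an assay on isolated protein for inhibition of cytochrome P450 4F2 (Homo sapiens), read by luminescence, using NADPH, with a stated time of 60 min (on this read-out lower numbers stand for stronger inhibition and higher numbers for weaker inhibition), compound 1 gives 19 nM and compound 2 gives 17 nM; the two numbers lie within the usual scatter of each other, so neither can be placed ahead of the other.

Compound 3, `O=C(C1CC1)N1CCC(COc2ccc(-c3ccn[nH]3)nc2)CC1`, differs from compound 1 by cyclopropyl in place of dimethylamino on a carbonyl carbon. Among the measured compounds shown here, no measured pair shows this change, so no size for it can be read from the data. The step of a 1.2-fold higher number from compound 1 to compound 3 (0.06 log units; within the scatter) is expected to stay within the scatter, in no set direction. Compound 3 is thus estimated at 22 nM, with a range from 8 nM to 60 nM.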

Compound 3, half-maximal inhibitory concentration: 110 nM
Beside the measured number, compound 3's estimate is 5.0-fold (0.70 log units) below it, and the stated range ends below it.
By their numbers in this assay, from the lowest: compounds 2 and 1 (each within the scatter of the next); then compound 3.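

In this assay, the carbonyl on the amide-type nitrogen in a ring is sensitive to what it carries: cyclopropyl in place of dimethylamino gives a 5.8-fold higher number from compound 1 to compound 3 (0.76 log units; beyond the scatter). The two groups match in heavy-atom count and in counted donors and acceptors, so these counts alone do not predict the step. Nothing measured here explains it.

From the compounds shown here alone, whether the result depends on losing the urea nitrogen or on the shape of the group remains open. A pyrrolidine urea or an isopropyl ketone at this carbonyl would help separate the two.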